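Capping the aminomethyl group: sulfamoyl against pivaloyl

The source may report more compounds than this note shows. Statements on the series, on what has been measured and on what is new or still open speak of the compounds shown alone.

Measured so far:
compound 1, `CS(=O)(=O)c1cccc(S(=O)(=O)c2ccc3c(c2)CCC[C@H]3CN)c1`, 3.98 nM
compound 2, `CN(C)S(=O)(=O)NC[C@@H]1CCCc2cc(S(=O)(=O)c3cccc(F)c3)ccc21`, 2 nM

Two compounds share the saturated bicyclic core bearing an arylsulfonyl group and a side-chain amine. In an assay on isolated protein for displacement of a labelled ligand from 5-hydroxytryptamine receptor 6 (Homo sapiens) (on this read-out lower numbers stand for stronger inhibition and higher numbers for weaker inhibition), compound 1 gives 3.98 nM, while compound 2, in which the amine carries a dimethylsulfamoyl group and the outer ring carries a fluorine, gives 2 nM. Compound 2 has the lower of the two numbers, but its gap to compound 1 lies within the scatter, so the two cannot be placed in order.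

The next compound, compound 3, `CC(C)(C)C(=O)NC[C@@H]1CCCc2cc(S(=O)(=O)c3cccc(F)c3)ccc21`, keeps everything of compound 2 except the cap on the amine: (tert-butyl)carbonyl in place of dimethylsulfamoyl on an amine nitrogen. A neutral carbonyl cap replaces a neutral sulfonyl cap on the same nitrogen. Because compound 1 with a free amine gives 3.98 nM and compound 2 with its dimethylsulfamoyl-bearing amine gives 2 nM, that group itself appears to be well tolerated, and no step beyond the scatter is expected for this exchange. The step from compound 2 to compound 3 is expected to be a 2.0-fold higher number from compound 2 to compound 3 (0.30 log units; within the scatter). Compound 3 is estimated at 4 nM, with a range from 1 nM to 16 nM.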

Compound 3, inhibition constant: 3.98 nM
Beside the measured number, compound 3's estimate is 1.0-fold (0.00 log units) above it; the range from low to high includes it.
By their numbers in this assay, from the lowest: compounds 2, 1 and 3 (each within the scatter of the next).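

Measured in this assay, the exchange of dimethylsulfamoyl for (tert-butyl)carbonyl on the amine nitrogen amounts to a 2.0-fold higher number from compound 2 to compound 3 (0.30 log units; within the scatter) and gives no order between the two compounds. For the compounds shown here, this is the first comparison in which only the cap on this nitrogen differs, and it shows that the position accepts a carbonyl cap as well as a sulfonyl cap, even though the entering group has lost the sulfur and the nitrogen of the leaving group and holds one hydrogen-bond acceptor fewer. Nothing measured here bears on why the two caps read alike.

Still open, on these data alone, is how this nitrogen would read with a smaller cap such as acetyl, or with a cap carrying a basic amine or a carboxylic acid. As far as these compounds go, compound 1 differs from compounds 2 and 3 both on the amine and on the outer ring, and the share of each of these two places in the read-out stays open.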